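The source may hold more compounds than are shown below. What is called first, only, known or untested is meant among the compounds shown, and "the series" means these compounds.

Compound 3 `COc1ccc2[nH]c(C(=O)N3CC(=O)N(Cc4ccccc4)[C@@H](CN4CC5CCCCC5C4)C3)cc2c1` is the only one of the three measured compounds that yields a number in an ADME assay on Vero cells (Chlorocebus sabaeus) for cytotoxicity, with a stated time of 7 days; a lower number here means that less compound is tolerated, a higher number that more compound is tolerated: compound 3 gives 8200 nM. Compound 1 `COc1ccc2[nH]c(C(=O)N3CC(=O)N(Cc4ccccc4)[C@@H](COc4ccccc4)C3)cc2c1` reaches only a limit of the assay, > 10000 nM. Compound 2 `COc1ccc2[nH]c(C(=O)N3CC(=O)N(Cc4ccccc4)[C@@H](CN4CCC(C)CC4)C3)cc2c1` likewise reaches only a limit, > 30000 nM. The step to compound 4 `COc1ccc2[nH]c(C(=O)N3CC(=O)N(Cc4ccccc4)[C@@H](CN4CCCc5ccccc54)C3)cc2c1` brings (a group of 10 heavy atoms (9 carbon, 1 nitrogen; one six-membered non-aromatic ring with 1 hetero atom, one six-membered aromatic ring of carbon only) in place of a group of 9 heavy atoms (8 carbon, 1 nitrogen; one five-membered non-aromatic ring with 1 hetero atom, one six-membered non-aromatic ring of carbon only), on a saturated chain carbon bound to a saturated ring carbon). Among the measured compounds shown here, two measured steps bear on this position: an at least 1.2-fold lower number from compound 1 to compound 3 (0.08 log units; that floor lies within the scatter) lies within the scatter, while an at least 3.6-fold lower number from compound 2 to compound 3 (0.56 log units; beyond the scatter) is at least modest. Compound 4 keeps a cyclic amine of similar size there, so the step is expected to stay small, a step of a 1.2-fold higher number from compound 3 to compound 4 (0.09 log units; within the scatter) in this assay. Compound 4 is therefore estimated at 10000 nM, with a range from 4000 nM to 30000 nM.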

Compound 4, half-maximal cytotoxic concentration: > 100000 nM
Compound 4: no number, only a limit; the forecaster's own chance of this, stated with the estimate: 40%; at least 10-fold (1.00 log units) between middle value and limit.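

The change from the saturated group of compound 3 to 1,2,3,4-tetrahydroquinolin-1-yl on this saturated chain carbon gives an at least 12-fold higher number from compound 3 to compound 4 (1.08 log units; beyond the scatter), so this assay can respond strongly to a swap between two cyclic amines. This is the largest step that can be read at this position. Compound 4 itself stands at a limit: the limit of > 100000 nM in this assay, at which 1 of the 4 values shown sits.

The steps from compound 1 and from compound 2 to compound 4 cannot be read. As far as these compounds go, it remains open how far beyond its limit compound 4 lies, and whether an indolin-1-yl or an N-methylanilino group would behave the same way.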